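A few compounds are considered here, and "the series" means these few. Any claim that something is new, unique, unknown or untested is made for them only; others in the source may bear on it.

Working notes on the series. Compound 1 `c1ccc(CNc2ccc3nc(-c4ccccc4)oc3n2)cc1` has no reported result in an assay on isolated protein for inhibition of Amine oxidase [flavin-containing] B (Homo sapiens), read by fluorescence, with a stated time of 1 h (a higher number here means a weaker inhibitor, a lower number a stronger inhibitor), entered as "not determined" (no result reported), so it offers no anchor. Among the compounds with values here, compound 2 `c1ccc(-c2nc3ccc(N4CCCCC4)nc3s2)cc1` is therefore the only compound of the series with a number: in this assay compound 2 gives 356 nM, and with no second number beside it there is nothing to rank it against, neither above nor below.

Compound 3 `Clc1ccc(-c2nc3ccc(N4CCCCC4)nc3s2)cc1` is the next compound to be measured in this assay. Compared with compound 2 it carries a single change, chloro in place of hydrogen on an aromatic carbon. Within the data shown here, no pair of measured compounds shows what such an exchange does here, so the size of the step has to be judged without a precedent from these data.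

The expectation is a modest gain in potency, a step of a 1.8-fold lower number from compound 2 to compound 3 (0.25 log units; within the scatter), which sits near the edge of the usual scatter rather than clearly beyond it. On that basis compound 3 is estimated at 200 nM in this assay, with a plausible range from 60 nM to 700 nM.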

Compound 3, half-maximal inhibitory concentration: 358 nM
The estimate for compound 3 lay 1.8-fold (0.25 log units) below the measured number; low and high end bracket the measured number.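

In this assay, within the data shown here, phenyl to 4-chlorophenyl gives the first readable step, a 1.0-fold higher number from compound 2 to compound 3 (0.00 log units; within the scatter), which lies within the scatter. At this place, on an aromatic carbon of a six-membered aromatic ring of carbon only and para to a large group, chloro in place of hydrogen therefore leaves the read-out without a discernible shift, and the series keeps its number with a heavier atom at this position. No measurement shown here accounts for this flat step.

On these data alone, what remains open is whether this position stays as flat for other groups, such as methoxy, trifluoromethyl, an amine or a carboxylic acid, since one exchange at one place cannot show whether other groups would also leave the number unchanged. Compound 1 gives "not determined" (no result reported), and so it offers no view of how the rest of the molecule contributes, leaving the position of chloro as the only part of the series for which any step can be read.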